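This account rests on a few compounds, and the source may have more. Where it says the series, first, only, none or still open, it means among the compounds named here.

Values in a functional assay on blood (Homo sapiens) for inhibition; on this read-out higher numbers stand for weaker inhibition and lower numbers for stronger inhibition:
- compound 1 `CCOC(=O)CCCOc1ccc(OCc2ccc3ccccc3n2)cc1C1(c2ccccc2)CC2CCC1C2`: 150 nM
- compound 2 `COc1ccc(OCc2ccc3ccccc3n2)cc1C1(c2ccccc2)CC2CCC1C2`: 1100 nM

Compound 2, at 1100 nM, has the higher of the two numbers in this assay, so it is the weaker inhibitor. Compound 3 `CS(=O)(=O)CCOc1ccc(OCc2ccc3ccccc3n2)cc1C1(c2ccccc2)CC2CCC1C2` differs from it by (methylsulfonyl)methyl in place of hydrogen on a saturated chain carbon bound to an oxygen on an aromatic ring. Among the compounds with values here, one measured step bears on this place: a 7.3-fold higher number from compound 1 to compound 2 (0.87 log units; beyond the scatter), with hydrogen replacing 2-(ethoxycarbonyl)ethyl. Read backwards, that step suggests that a chain added here may lower the number, though a different chain may not match it, so a somewhat smaller step is expected. The expected change is a 3.1-fold lower number from compound 2 to compound 3 (0.50 log units; beyond the scatter). For compound 3 the estimate is 350 nM, with an expected range of 120 nM to 1000 nM.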

Compound 3, half-maximal inhibitory concentration: 114 nM
Compound 3: the middle estimate sits 3.1-fold (0.49 log units) above what was measured; the whole stated range lies above it.
By their numbers in this assay, from the lowest: compounds 3 and 1 (each within the scatter of the next); then compound 2.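

Putting 2-(methylsulfonyl)ethyl in place of methyl gives a 9.6-fold lower number from compound 2 to compound 3 (0.98 log units; beyond the scatter) and so shows that the gain at this position does not depend on the ethoxycarbonyl group of compound 1. Swapping that group for methylsulfonyl gives a 1.3-fold lower number from compound 1 to compound 3 (0.12 log units; within the scatter) and leaves the two chains indistinguishable here. Nothing measured explains why either chain helps. Still open, as far as these compounds go, is whether an amine or a carboxylic acid at the end of the chain would hold this level, and whether a shorter or longer chain would serve as well.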